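The source may report more compounds than this note shows. Statements on the series, on what has been measured and on what is new or still open speak of the compounds shown alone.

Of the compounds shown here, two have been measured in a functional assay for agonist activity at Glucose-dependent insulinotropic receptor (Mus musculus), read by cAMP accumulation (a lower number here means a smaller maximal response, a higher number a larger maximal response), and compound 3 is still waiting for its result. Compound 1 `CC1(COC(=O)N2CC3COCC(C2)C3Oc2ncnc(Nc3ccc(C#N)cc3Cl)c2F)COC1` gives 46% in this assay. Compound 2 `CC1(OC(=O)N2CC3COCC(C2)C3Oc2ncnc(Oc3ccccc3F)c2F)CC1` gives 136%, which is the higher of the two numbers, and its gap to compound 1 lies well beyond the usual scatter. Compound 1 and compound 2 differ in more than one place, so the two values alone do not say which part of the structure carries the difference.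

Compound 3 `CC1(OC(=O)N2CC3COCC(C2)C3Oc2ncnc(Nc3ccc(F)cc3F)c2F)CC1` is built from compound 2 by one change: (2,4-difluorophenyl)amino in place of 2-fluorophenoxy on an aromatic carbon. Within the data shown here, compound 1, the only measured compound with an amino link of this kind, sits far below compound 2, yet its carbamate tail also differs, so that comparison is only a loose hint. On that hint a downward step is expected for the move from compound 2 to compound 3, a number 46 percentage points lower from compound 2 to compound 3 (beyond the scatter), of a size that should exceed the scatter. Compound 3 is therefore estimated to reach 90% in this assay, with a plausible range from 50% to 130%.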

Compound 3, largest response reached (reported as percent of maximum), in percent of the reference or control that the assay uses: 73%
Compound 3: middle estimate off by 17 percentage points, on the high side; the range from low to high includes it.
By their numbers in this assay, from the lowest: compound 1; then compound 3; then compound 2.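

Compound 2 and compound 3 differ in one place only, so this pair gives a clean reading of this aromatic carbon in this assay, which the comparison of compound 1 and compound 2 could not: the maximal response is a number 63 percentage points lower from compound 2 to compound 3 (beyond the scatter). The change is not a single-atom swap, however, since the oxygen link gives way to a nitrogen link carrying a hydrogen-bond donor and the aromatic ring gains a second fluorine, and this one step cannot separate the two. Nothing measured here explains the fall in response.

What stays open is which of the two alterations accounts for the step: a 2,4-difluorophenoxy group or a (2-fluorophenyl)amino group on the same carbon, each carrying only one of them, would pull the two apart. Going by these compounds, it is also open whether a step of this size would appear with a different carbamate tail, or whether a methylamino link, with a methyl group in place of the hydrogen on the linking nitrogen, would behave like the oxygen link or the nitrogen link.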